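Replacing a piperidine ring in a weak growth inhibitor

A few compounds are considered here, and "the series" means these few. Any claim that something is new, unique, unknown or untested is made for them only; others in the source may bear on it.

This account follows a single change made to compound 1, `Cc1nc(Nc2ccc3sc(C(=O)Nc4c(C)cccc4Cl)cc3c2)cc(N2CCCCC2)n1`. In a functional assay on K562 cells (Homo sapiens) for inhibition, read by MTT assay and WST assay, with a stated time of 72 h, tested at 10 uM (a lower number here means less inhibition of growth, a higher number more inhibition of growth at the concentration tested), compound 1 gives 8.78%, the lowest of the three numbers measured. The two other compounds share a different core: compound 2, `CCN(CC)CCCOc1cc2ncnc(Nc3ccc4sc(C(=O)Nc5c(C)cccc5Cl)cc4c3)c2cc1OC`, gives 72.5%, and compound 3, `COc1cc2c(Nc3ccc4sc(C(=O)Nc5c(C)cccc5Cl)cc4c3)ncnc2cc1OCCCN1CCCCC1`, gives 71.8%. Both stand well apart from compound 1, which lies beyond the scatter from each of them.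

The new compound is compound 4, `CCN1CCN(c2cc(Nc3ccc4sc(C(=O)Nc5c(C)cccc5Cl)cc4c3)nc(C)n2)CC1`, which differs from compound 1 in one place: 4-ethylpiperazin-1-yl in place of piperidin-1-yl on an aromatic carbon. Among the compounds with values here, the only measured step, a number 0.7 percentage points lower from compound 2 to compound 3 (within the scatter), exchanges one saturated amine for another on a chain and leaves the result within the scatter. That step sits on a different core and a different position, so it bears on the present change only loosely, suggesting that swapping one saturated amine ring for another need not move the number much. Compound 4 is therefore expected to stay close to compound 1, with a step of a number 5.2 percentage points higher from compound 1 to compound 4 (within the scatter) judged not beyond the scatter, and its estimated value is 14%, within a range from 2% to 38%.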

Compound 4, percent growth inhibition at one concentration: 33.9%
Compound 4: the middle estimate sits 19.9 percentage points below what was measured; the range from low to high includes it.
By their numbers in this assay, from the lowest: compound 1; then compound 4; then compounds 3 and 2 (each within the scatter of the next).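

In this assay the exchange of piperidin-1-yl for 4-ethylpiperazin-1-yl on an aromatic carbon next to the ring nitrogen comes with a number 25.1 percentage points higher from compound 1 to compound 4 (beyond the scatter) and so shows that, on the core of compound 1, the number responds to which saturated amine ring stands at this place. The earlier step of a number 0.7 percentage points lower from compound 2 to compound 3 (within the scatter) lay on a chain of another core and gave no such sign, so a swap of one saturated amine for another cannot be taken as neutral across these compounds. Nothing at hand gives a measured reason for the rise.

The compounds shown leave open whether the second ring nitrogen or the ethyl group carries the change. A piperazine ring without the ethyl group, or a morpholine ring, at this place would separate the two.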